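Compound 1 to compound 4: a ring replaces a chain

The source may report more compounds than this note shows. Statements on the series, on what has been measured and on what is new or still open speak of the compounds shown alone.

In an ADME assay (liver) for metabolic stability, with Liver microsome (Homo sapiens) as the target, using microsomes and NADPH, with a stated time of 30 min, tested at 1 uM (a lower number here means slower removal, a higher number faster removal of the compound), compound 1 `COCC#Cc1cc(C(O)(C(F)(F)F)C(F)(F)F)cnc1N1CCN(S(=O)(=O)c2ccc(N)nc2)CC1` gives 15 mL.min-1.g-1, and compound 3 `CCn1cc(-c2cc(C(O)(C(F)(F)F)C(F)(F)F)cnc2N2CCN(S(=O)(=O)c3ccc(N)nc3)CC2)cn1` gives 20 mL.min-1.g-1. Compound 2 `Nc1ccc(S(=O)(=O)N2CCN(c3ncc(C(O)(C(F)(F)F)C(F)(F)F)cc3C#CCCO)CC2)cn1` is reported only as a limit, < 14 mL.min-1.g-1. Compound 1 therefore stands clearly apart from neither of its two neighbours.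

Compound 4 `Cc1csc(-c2cc(C(O)(C(F)(F)F)C(F)(F)F)cnc2N2CCN(S(=O)(=O)c3ccc(N)nc3)CC2)c1` carries 4-methylthiophen-2-yl in place of 3-methoxyprop-1-yn-1-yl on an aromatic carbon.

For the measured compounds named here, no measured compound carries this new ring, so the nearest guide is compound 3, where 1-ethyl-1H-pyrazol-4-yl took the place of the same chain. That change gave a 1.3-fold higher number from compound 1 to compound 3 (0.12 log units; within the scatter). The other two steps are an at least 1.0-fold lower number from compound 1 to compound 2 (0.02 log units; that floor lies within the scatter) and an at least 1.4-fold higher number from compound 2 to compound 3 (0.15 log units; that floor lies within the scatter), and both rest on a limit. None of the three steps leaves the usual scatter, so only a small move is expected, in the direction seen for compound 3. The expected step is a 1.7-fold higher number from compound 1 to compound 4 (0.22 log units; within the scatter). For compound 4 the estimated value is 25 mL.min-1.g-1, with an expected range of 14 mL.min-1.g-1 to 50 mL.min-1.g-1.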

Compound 4, intrinsic clearance in microsomes: 29 mL.min-1.g-1
Estimate against measurement, compound 4: 1.2-fold (0.06 log units) below; low and high end bracket the measured number.
By their numbers in this assay, from the lowest: compounds 1, 3 and 4 (each within the scatter of the next). At a limit, below all of these: compound 2.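

Swapping the chain for a ring at this position, with the sulfur-containing 4-methylthiophen-2-yl, gives a 1.9-fold higher number from compound 1 to compound 4 (0.29 log units; within the scatter), and exchanging one five-membered aromatic ring for another gives a 1.5-fold higher number from compound 3 to compound 4 (0.16 log units; within the scatter), so in this assay neither change leaves the usual scatter. For the compounds shown here, the only step among the new ones that goes beyond the scatter is an at least 2.0-fold higher number from compound 2 to compound 4 (0.31 log units; beyond the scatter), where the ring replaces 4-hydroxybut-1-yn-1-yl. That size is only a floor, as compound 2 is reported as a limit and not as a number: the limit of < 14 mL.min-1.g-1 in this assay, at which 1 of the 4 values shown sits.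

The compounds shown leave open whether the methyl on the new ring plays any part in the result, as no unsubstituted thiophen-2-yl appears among them. They also leave open how an amine or a carboxylic acid at this position would behave.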